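Nitro on the phenyl ring: from compound 2 to compound 3

A few compounds are considered here, and "the series" means these few. Any claim that something is new, unique, unknown or untested is made for them only; others in the source may bear on it.

The series rests on the core of compound 2 `O=c1ccc2cc(OCc3cn(-c4ccccc4)nn3)ccc2o1`. For the measured compounds named here, compound 1 `O=c1ccc2cc(OCc3cc(-c4ccccc4[N+](=O)[O-])no3)ccc2o1` carries the same core, but in a functional assay on HL-60 cells (Homo sapiens) for cytotoxicity, read by MTT assay, with a stated time of 48 h (a lower number here means a stronger inhibitor, a higher number a weaker inhibitor), compound 1 is recorded as "not determined" (no result reported), so compound 2 holds the only value in this assay, at 41600 nM. Compound 3 `O=c1ccc2cc(OCc3cn(-c4ccccc4[N+](=O)[O-])nn3)ccc2o1` differs from compound 2 by nitro in place of hydrogen on an aromatic carbon. Going by the values given here, no pair of measured compounds shows this change, so its size is open; the step is expected to stay near the scatter, with a slight gain if anything, as a 1.4-fold lower number from compound 2 to compound 3 (0.14 log units; within the scatter). Compound 3 is estimated at 30000 nM, with a range from 10000 nM to 90000 nM.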

Compound 3, half-maximal inhibitory concentration: 44600 nM
Compound 3: the middle estimate sits 1.5-fold (0.17 log units) below what was measured; measured number inside the range.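

In this assay, for the compounds shown here, the replacement of phenyl by 2-nitrophenyl reads a 1.1-fold higher number from compound 2 to compound 3 (0.03 log units; within the scatter) and gives the first measured step. With nitro on an aromatic carbon ortho to a large group, compound 2 and compound 3 cannot be told apart in this assay. Going by these compounds, it remains open whether an amine, a carboxylic acid or a methoxy group in the same place would give a step beyond the scatter, and whether nitro elsewhere on the phenyl ring would do so. No measurement at hand bears on the reason for this result.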